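Thiomorpholine amide in the alkyne series

The source may report more compounds than this note shows. Statements on the series, on what has been measured and on what is new or still open speak of the compounds shown alone.

Compound 1 `CC1CCC(NC(=O)c2ccc(C#Cc3ccccc3)nc2)CC1` gives 1200 nM in a functional assay on BHK cells for positive allosteric modulation of metabotropic glutamate receptor 5 (Homo sapiens), read by FLIPR and calcium flux; a higher number here means that more compound is needed for the effect, a lower number that less compound is needed. Compound 2 `O=C(NCc1ccsc1)c1ccc(C#Cc2ccccc2)cc1` gives 1200 nM in this assay; the two values sit within the scatter of each other, so compound 1 stands level with compound 2. Compound 3 `O=C(c1ccc(C#Cc2ccccc2)nc1)N1CCSCC1` carries thiomorpholin-4-yl in place of (4-methylcyclohexyl)amino on a carbonyl carbon. Going by the values given here, no measured pair shows a change of this kind, so its size is open; the hydrogen-bond donor leaves, and a modest step toward a higher value is expected, a 2.1-fold higher number from compound 1 to compound 3 (0.32 log units; beyond the scatter). Compound 3 is estimated at 2500 nM, with a range from 800 nM to 8000 nM.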

Compound 3, half-maximal effective concentration: 46 nM
The estimate for compound 3 lay 54-fold (1.74 log units) above the measured number; measured number outside the range, below it.
By their numbers in this assay, from the lowest: compound 3; then compounds 1 and 2 (each within the scatter of the next).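

Going by these compounds alone, on a carbonyl carbon, this change moves the number far more than the earlier compounds could suggest: in this assay, thiomorpholin-4-yl in place of (4-methylcyclohexyl)amino gives a 26-fold lower number from compound 1 to compound 3 (1.42 log units; beyond the scatter). Loss of the amide hydrogen is thus compatible with a much lower number in this series. No measurement on hand explains the size of this step.

The amide hydrogen and the ring change together, so their shares in the step remain unseparated. Also open, on these data alone, is whether sulfur matters, which morpholine or piperidine in place of thiomorpholine would test.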